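Methyl on the amide-type nitrogen of compound 3

The source may report more compounds than this note shows. Statements on the series, on what has been measured and on what is new or still open speak of the compounds shown alone.

In a functional assay on the whole organism for antagonist activity, with Mus musculus as the target (a lower number here means that less compound is needed, a higher number that more compound is needed for the effect), compound 3 (`COC(=O)NCC#CCn1cncc1C`) stands at 80 mg/kg and compound 2 (`CC(=O)NCC#CCn1cncc1C`) stands at 66 mg/kg, so the two sit level within the scatter. Compound 1 (`CC(C#CCn1ccnc1)N1CCCC1=O`) gives 3.7 mg/kg, a number lower than that of compound 3 by a distance beyond the scatter.

Compound 4 (`COC(=O)N(C)CC#CCn1cncc1C`) comes from compound 3 through methyl in place of hydrogen on an amide-type nitrogen. Among the compounds with values here, no measured pair changes this nitrogen. Within the data shown here, the only measured step, a 1.2-fold higher number from compound 2 to compound 3 (0.08 log units; within the scatter), is methoxy in place of methyl on a carbonyl carbon, which is a different place, so it bears on the new change only indirectly. Compound 1 at 3.7 mg/kg also has no hydrogen on its amide-type nitrogen, but it differs from compound 3 elsewhere as well, which allows only a weak lean towards a lower number.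

No step beyond the scatter is therefore expected in this assay, and the estimated change is a 1.6-fold lower number from compound 3 to compound 4 (0.20 log units; within the scatter) as a best guess. The expected value for compound 4 is 50 mg/kg with an estimated range of 15 mg/kg to 150 mg/kg around it.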

Compound 4, dose for half-maximal effect: 5.4 mg/kg
Compound 4: middle estimate off by 9.3-fold (0.97 log units), on the high side, outside the stated range (below it).
By their numbers in this assay, from the lowest: compounds 1 and 4 (each within the scatter of the next); then compounds 2 and 3 (each within the scatter of the next).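

Methyl in place of hydrogen on the amide-type nitrogen gives the only step beyond the scatter among the single-place changes in the series: in this assay it gives a 15-fold lower number from compound 3 to compound 4 (1.17 log units; beyond the scatter), whereas the change on the carbonyl carbon gave only a 1.2-fold higher number from compound 2 to compound 3 (0.08 log units; within the scatter), which is within the scatter. The outcome at this position could not be read from that earlier step, and it shows that the amide hydrogen of compound 3 is not required for the effect, since compound 4 lacks it and gives 5.4 mg/kg in this assay. No supporting measurement is available to account for the size of this step.

Still open, from the compounds shown here alone, is whether ethyl or a longer chain on this nitrogen would keep, extend or lose the step seen with methyl. Also open, going by these compounds, is whether the same methyl on the amide-type nitrogen of compound 2, which carries methyl rather than methoxy on the carbonyl carbon, would give a step of similar size.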